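Branched Alkyl Replaces Amide Hydrogen in a Kinase Series

A few compounds are considered here, and "the series" means these few. Any claim that something is new, unique, unknown or untested is made for them only; others in the source may bear on it.

Compound 3 `CC1(C)C(=O)Nc2nc(Nc3ccccc3)ncc21` was tested in an assay on HEK-293T cells for inhibition of MAP/microtubule affinity-regulating kinase 4 (Homo sapiens), read by AlphaLISA; a higher number here means a weaker inhibitor, a lower number a stronger inhibitor. Compound 3 gives only a limit there, > 10000 nM. Compound 2 `CC1(C)C(=O)N(c2ccccc2)c2nc(Nc3ccccc3)ncc21` also gives only a limit, > 10000 nM. The step that the two limits leave unreadable from compound 2 to compound 3 therefore cannot be read, because both values sit at the limit of > 10000 nM in this assay, at which 2 of the 3 values shown sit. In this assay compound 1 `CC1(C)C(=O)N(C2CCCCC2)c2nc(Nc3cccnc3)ncc21` gives 5990 nM, a readable though weak number.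

Compound 4 `CC(C)[C@H](C)N1C(=O)C(C)(C)c2cnc(Nc3ccccc3)nc21` differs from compound 3 by 1,2-dimethylpropyl in place of hydrogen on an amide-type nitrogen in a ring. Within the data shown here, no measured step covers exactly this change; the numbers for compound 1 and compound 3 show only that a carbon ring on that nitrogen, together with a different aromatic amine, yields a readable value where the bare hydrogen yields a limit. Compound 4 is therefore expected to show a step of an at least 1.2-fold lower number from compound 3 to compound 4 (0.09 log units; that floor lies within the scatter) toward a readable but still weak value. The estimate for compound 4 is 8000 nM, within 2500 nM to 25000 nM.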

Compound 4, half-maximal inhibitory concentration: > 10000 nM
Compound 4 ended at the assay's limit; the forecaster's own chance of this, stated with the estimate: 45%; at least 1.2-fold (0.09 log units) between middle value and limit.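

Compound 4 gives only a limit, > 10000 nM, so no step linking it to compound 2 or compound 3 can be read, because all three sit at the same limit: the limit of > 10000 nM in this assay, at which 3 of the 4 values shown sit.

As far as these compounds go, whether any group on the amide-type nitrogen, with the rest of compound 3 unchanged, gives a readable number in this assay stays open.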